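The source may report more compounds than this note shows. Statements on the series, on what has been measured and on what is new or still open speak of the compounds shown alone.

Measured compounds:
compound 1 `Nc1scc(CN2CCN(c3cccc(Cl)c3Cl)CC2)c1C(=O)c1ccc(Cl)cc1`: 1%
compound 2 `Nc1scc(CN2CCN(c3cc(Cl)cc(Cl)c3)CC2)c1C(=O)c1ccc(Cl)cc1`: -1%
compound 3 `Nc1scc(CN2CCN(c3ccc(Cl)cc3F)CC2)c1C(=O)c1ccc(Cl)cc1`: -9.2%

In a functional assay on CHO cells with adenosine receptor A1 (Homo sapiens) as the target, read by cAMP accumulation and immunoassay, with a stated time of 6 min, tested at 0.01 uM (a higher number here means a weaker effect of the compound at the concentration tested, a lower number a stronger effect), compound 3 gives -9.2%, the lowest of the three numbers. The step of a number 8.2 percentage points lower from compound 2 to compound 3 (within the scatter) lies within the scatter, while a number 10.2 percentage points lower from compound 1 to compound 3 (beyond the scatter) lies beyond it, though only modestly. Compound 4 `Nc1scc(CN2CCN(c3ccc([N+](=O)[O-])cc3)CC2)c1C(=O)c1ccc(Cl)cc1` differs from compound 3 in one place: 4-nitrophenyl in place of 4-chloro-2-fluorophenyl on an amine nitrogen in a ring. Every measured step is a change of the aryl group on the same ring nitrogen: a number 2 percentage points lower from compound 1 to compound 2 (within the scatter), a number 10.2 percentage points lower from compound 1 to compound 3 (beyond the scatter) and a number 8.2 percentage points lower from compound 2 to compound 3 (within the scatter). None of these involves a 4-nitrophenyl, and all three values sit close to zero, so a step of a number 6.2 percentage points higher from compound 3 to compound 4 (within the scatter) of no size beyond the scatter is expected for compound 4. Compound 4 is therefore estimated at -3%, with a range from -15% to 10%.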

Compound 4, a percentage reported as activity, at one concentration (the size of the read-out at that concentration, not a potency): -12%
For compound 4 the middle estimate is 9 percentage points above the measured one, and the stated range covers the measured number.
By their numbers in this assay, from the lowest: compounds 4, 3, 2 and 1 (each within the scatter of the next, the first and the last beyond it).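

In this assay, among these compounds, the 4-nitrophenyl on the ring nitrogen is the first aryl group in this set without a halogen, yet it cannot be told apart from the 4-chloro-2-fluorophenyl (a number 2.8 percentage points lower from compound 3 to compound 4 (within the scatter)). Against the two dichlorophenyl compounds, the same change gives modest steps (a number 11 percentage points lower from compound 2 to compound 4 (beyond the scatter); a number 13 percentage points lower from compound 1 to compound 4 (beyond the scatter)). This position therefore tolerates the loss of halogen and the entry of a nitro group without the number rising. Nothing available explains these steps. On these data alone, how an aryl group bearing a methoxy or a carboxylic acid, or a plain alkyl chain in place of the aryl group, would read on this nitrogen stays open.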